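Difluoro for dichloro on the carbonyl-side aryl ring

The compounds below may be only part of what the source reports. "The series", "measured", "known", "first", "only" and "open" are said of these compounds alone.

Working notes on a small set of enones sharing a pyrazole-linked core. In a functional assay on K562 cells (Homo sapiens) for inhibition, read by sulforhodamine B assay, with a stated time of 48 h (a lower number here means a stronger inhibitor of growth, a higher number a weaker inhibitor of growth), compound 1 `COc1cc(-c2cc(/C=C/C(=O)c3ccc(N)cc3)[nH]n2)cc(OC)c1OC` gives 720 nM. Compound 3 `COc1ccc(-c2cc(/C=C/C(=O)c3cc(OC)c(OC)c(OC)c3)[nH]n2)cc1OC`, which carries the trimethoxy pattern on the carbonyl-side ring instead, gives 730 nM. Compound 2 `COc1cc(-c2cc(/C=C/C(=O)c3ccc(Cl)c(Cl)c3)[nH]n2)cc(OC)c1OC` gives 4960 nM and so stands as the highest number of the three, separated from both compound 3 and compound 1 by gaps beyond the scatter. Going by the values given here, the one measured step at the carbonyl carbon, a 6.9-fold higher number from compound 1 to compound 2 (0.84 log units; beyond the scatter), shows that exchanging the aryl group at this position can move the number by a modest amount.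

Compound 4 `COc1cc(-c2cc(/C=C/C(=O)c3ccc(F)c(F)c3)[nH]n2)cc(OC)c1OC` is the unmeasured member: 3,4-difluorophenyl in place of 3,4-dichlorophenyl on a carbonyl carbon. Among the compounds with values here, no measured pair compares one dihalogenated ring with another, so the only guide is that the dichloro compound 2 sits at the weak end of the set. The expectation is therefore a small step, if any, towards lower numbers, a 1.7-fold lower number from compound 2 to compound 4 (0.22 log units; within the scatter), and compound 4 is estimated at 3000 nM within a range of 1200 nM to 8000 nM.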

Compound 4, concentration for 50% growth inhibition: 3310 nM
Beside the measured number, compound 4's estimate is 1.1-fold (0.04 log units) below it, within the range that was stated.
By their numbers in this assay, from the lowest: compounds 1 and 3 (each within the scatter of the next); then compounds 4 and 2 (each within the scatter of the next).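

In this assay, replacing one dihalogenated ring with the other on the carbonyl carbon gives no readable change (a 1.5-fold lower number from compound 2 to compound 4 (0.18 log units; within the scatter)), so 3,4-difluorophenyl and 3,4-dichlorophenyl cannot be told apart at this position. The 3,4-difluorophenyl ring also keeps a gap beyond the scatter from the 4-aminophenyl ring (a 4.6-fold higher number from compound 1 to compound 4 (0.66 log units; beyond the scatter)), so the higher number seen with the dichloro ring is not confined to chlorine. No measurement is available here that bears on the reason for these numbers.

The compounds shown leave open whether the lower number belongs to the amine itself, which 4-hydroxyphenyl or 4-acetamidophenyl on the same carbonyl carbon could test. A single fluorine or a trifluoromethyl group on this ring would show whether the match between the two dihalogenated rings extends to other halogen patterns.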